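Hexyl for methoxyphenyl on a di-N-oxide quinoxaline series

The source may report more compounds than this note shows. Statements on the series, on what has been measured and on what is new or still open speak of the compounds shown alone.

Measured so far:
Compound 1, `[O-][n+]1nc(NCOC2CCCCC2)[n+]([O-])c2ccccc21`: 4390 nM
Compound 2, `[O-][n+]1nc(NCOCc2ccc(C(F)(F)F)cc2)[n+]([O-])c2ccccc21`: 390 nM
Compound 3, `COc1ccc(COCNc2n[n+]([O-])c3ccccc3[n+]2[O-])cc1`: 4060 nM

In a functional assay on KB cells (Homo sapiens) for cytotoxicity, read by MTT assay, with a stated time of 72 h (on this read-out lower numbers stand for stronger inhibition and higher numbers for weaker inhibition), compound 3 gives 4060 nM, the second highest of the three numbers; compound 1 gives 4390 nM, within the scatter of compound 3, while compound 2 gives 390 nM, a number well below both. For the measured compounds named here, the only one-place step among them, a 10-fold higher number from compound 2 to compound 3 (1.02 log units; beyond the scatter), concerns a swap on the aromatic ring. Compound 4, `CCCCCCCOCNc1n[n+]([O-])c2ccccc2[n+]1[O-]`, differs from compound 3 as follows: hexyl in place of 4-methoxyphenyl on a saturated chain carbon bound to an oxygen on a saturated carbon. Going by the values given here, no measured step bears directly on removing the ring itself. Compound 1 and compound 3 show that two different groups at this position can give much the same number. Compound 4 is therefore expected to sit near compound 3, with a 1.0-fold lower number from compound 3 to compound 4 (0.01 log units; within the scatter), at about 4000 nM, between 1500 nM and 11000 nM.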

Compound 4, half-maximal inhibitory concentration: 2520 nM
For compound 4 the middle estimate is 1.6-fold (0.20 log units) above the measured one; measured number inside the range.
By their numbers in this assay, from the lowest: compound 2; then compounds 4, 3 and 1 (each within the scatter of the next).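

In this assay, removing the aromatic ring at this position does not move the number beyond the scatter: the change gives a 1.6-fold lower number from compound 3 to compound 4 (0.21 log units; within the scatter), and the comparison with the saturated ring gives a 1.7-fold lower number from compound 1 to compound 4 (0.24 log units; within the scatter). A plain chain, a saturated ring and a methoxy-bearing aromatic ring therefore cannot be told apart here, although compound 2 goes against this with 390 nM. No available evidence accounts for these results.

The compounds shown leave open whether a longer chain or an amine at the chain end would keep this level. They also leave open whether a nitrile on the aromatic ring would track compound 2 or compound 3.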